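Carbamate chain length in an aryl selenocyanate series

The source may report more compounds than this note shows. Statements on the series, on what has been measured and on what is new or still open speak of the compounds shown alone.

Three carbamates on a shared core have been measured in a functional assay on HT-29 cells (Homo sapiens) for cytotoxicity, read by MTT assay, with a stated time of 72 h; a higher number here means that more compound is tolerated, a lower number that less compound is tolerated. Compound 1 `CCCOC(=O)Nc1ccc([Se]C#N)cc1` gives 75400 nM. Compound 2 `CCCCOC(=O)Nc1ccc([Se]C#N)cc1` gives 63700 nM. Compound 3 `CCCCCCOC(=O)Nc1ccc([Se]C#N)cc1` gives 69900 nM, the second highest of the three numbers; its nearest neighbour is compound 1, with a 1.1-fold lower number from compound 1 to compound 3 (0.03 log units; within the scatter), and its furthest is compound 2, with a 1.1-fold higher number from compound 2 to compound 3 (0.04 log units; within the scatter). Neither gap leaves the scatter.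

Compound 4 `CCOC(=O)Nc1ccc([Se]C#N)cc1` is not yet measured. Against compound 3 the change is hydrogen in place of butyl on a saturated chain carbon, two bonds along the chain from an oxygen next to a carbonyl group, a shortening of the alkyl chain. Within the data shown here, the steps that bear on it are the chain extensions already in hand: a 1.2-fold lower number from compound 1 to compound 2 (0.07 log units; within the scatter), a 1.1-fold lower number from compound 1 to compound 3 (0.03 log units; within the scatter) and a 1.1-fold higher number from compound 2 to compound 3 (0.04 log units; within the scatter). None of them moved the number beyond the scatter, so lengthening this chain left this assay flat. Removing butyl runs in the opposite direction along the same chain, and no step beyond the scatter is expected. Compound 4 is therefore estimated at 70000 nM, with a range of 35000 nM to 140000 nM, meaning an expected step of a 1.0-fold higher number from compound 3 to compound 4 (0.00 log units; within the scatter).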

Compound 4, concentration lethal to 50% of the cells: 66600 nM
Compound 4: the middle estimate sits 1.1-fold (0.02 log units) above what was measured, and the stated range covers the measured number.
By their numbers in this assay, from the lowest: compounds 2, 4, 3 and 1 (each within the scatter of the next).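

Shortening the chain, not only lengthening it, leaves this assay flat at this position, with a 1.0-fold lower number from compound 3 to compound 4 (0.02 log units; within the scatter) for hydrogen in place of butyl. The smaller cuts read alike, with a 1.0-fold higher number from compound 2 to compound 4 (0.02 log units; within the scatter) for hydrogen in place of ethyl and a 1.1-fold lower number from compound 1 to compound 4 (0.05 log units; within the scatter) for hydrogen in place of methyl. All four compounds, from the ethyl chain to the hexyl chain, therefore stand within the scatter of each other, and no chain length among them can be set apart.

As far as these compounds go, whether a longer chain than hexyl, or an amine or a carboxylic acid carried on this chain, would move the number stays open. No evidence at hand bears on why the number stays flat across these chains.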